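The source may hold more compounds than are shown below. What is called first, only, known or untested is meant among the compounds shown, and "the series" means these compounds.

In an assay on HEK293 cells for displacement of a labelled ligand from Melanocortin receptor 4 (Homo sapiens) (a lower number here means a stronger inhibitor, a higher number a weaker inhibitor), compound 1 `CCC(C)[C@H](N)c1cc(C(F)(F)F)ccc1N1CCN(C(=O)CCc2ccc(Cl)cc2)CC1` gives 86 nM, compound 2 `COc1cccc(CCC(=O)N2CCN(c3ccc(C(F)(F)F)cc3[C@@H](N)CC(C)C)CC2)c1` gives 4000 nM, and compound 3 `CC(C)C[C@H](N)c1cc(C(F)(F)F)ccc1N1CCN(C(=O)CCc2c(Cl)cccc2Cl)CC1` gives 2600 nM. Compound 3 thus stands second highest of the three numbers, nearest to compound 2 and far from compound 1. Among the compounds with values here, the one step that bears on the next change, a 1.5-fold lower number from compound 2 to compound 3 (0.19 log units; within the scatter), shows that exchanging the aryl group on a saturated chain carbon, two bonds along the chain from a carbonyl carbon, left the number essentially where it was. Compound 4 `CC(C)C[C@H](N)c1cc(C(F)(F)F)ccc1N1CCN(C(=O)CCc2cn(C)c3ccccc23)CC1` carries the change (1-methyl-1H-indol-3-yl in place of 2,6-dichlorophenyl on a saturated chain carbon, two bonds along the chain from a carbonyl carbon). Within the data shown here, no measured step covers this group, so in this assay only a modest step is expected, with slight room toward a lower number. For compound 4 the expected value is 1500 nM (range 400 nM to 6000 nM), which means an expected step of a 1.7-fold lower number from compound 3 to compound 4 (0.24 log units; within the scatter).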

Compound 4, inhibition constant: 3000 nM
Compound 4: the middle estimate sits 2.0-fold (0.30 log units) below what was measured; the measured number falls inside the stated range.
By their numbers in this assay, from the lowest: compound 1; then compounds 3, 4 and 2 (each within the scatter of the next).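

In this assay, 1-methyl-1H-indol-3-yl reads the same as 2,6-dichlorophenyl on a saturated chain carbon, two bonds along the chain from a carbonyl carbon (a 1.2-fold higher number from compound 3 to compound 4 (0.06 log units; within the scatter)), and the same as 3-methoxyphenyl (a 1.3-fold lower number from compound 2 to compound 4 (0.12 log units; within the scatter)). This position therefore now tolerates a group with a five-membered aromatic ring as well as two with a single six-membered aromatic ring, with no separation among compounds 2, 3 and 4. No evidence on the reason for this is at hand. Still open, from the compounds shown here alone, is whether an amine or a carboxylic acid in place of the aryl group, or a longer chain, would depart from this level.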